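A few compounds are considered here, and "the series" means these few. Any claim that something is new, unique, unknown or untested is made for them only; others in the source may bear on it.

Compound 1 `CC(C)[C@H](NC(=O)COc1cccc2ccccc12)C(=O)N[C@@H](CC(=O)O)C(=O)COc1ccccc1`: 14000 nM
Compound 2 `CC(C)[C@H](NC(=O)COc1cccc2ccccc12)C(=O)N[C@@H](CC(=O)O)C(=O)COc1cccc2ccccc12`: > 100000 nM (a limit)
Compound 3 `CC(C)[C@H](NC(=O)COc1cccc2ccccc12)C(=O)N[C@@H](CC(=O)O)C(=O)COc1cccc(C(F)(F)F)c1`: > 100000 nM (a limit)

In a functional assay on Jurkat cells (Homo sapiens) (a lower number here means a stronger inhibitor, a higher number a weaker inhibitor), compound 3 has no numerical value, only the limit > 100000 nM. The series reaches (the limit of > 100000 nM in this assay, at which 2 of the 3 values shown sit). Compound 4 `CC(C)[C@H](NC(=O)COc1cccc2ccccc12)C(=O)N[C@@H](CC(=O)O)C(=O)COc1ccc(OC(F)(F)F)cc1` carries 4-(trifluoromethoxy)phenyl in place of 3-(trifluoromethyl)phenyl on an oxygen on a saturated carbon.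

For the measured compounds named here, two measured steps bear on this change, and both lie beyond the scatter. One is an at least 7.1-fold higher number from compound 1 to compound 3 (0.85 log units; beyond the scatter), and the other is an at least 7.1-fold higher number from compound 1 to compound 2 (0.85 log units; beyond the scatter). Both replace the unsubstituted phenyl of compound 1, and neither replacement retains its activity. The third step, a step that the two limits leave unreadable from compound 2 to compound 3, has no readable size. Compound 4 also departs from that unsubstituted phenyl, so it is expected to remain weak, probably at the limit again, with little recovery toward compound 1. The expected change is small and cannot be read firmly against a limit: an at least 1.4-fold lower number from compound 3 to compound 4 (0.15 log units; that floor lies within the scatter). Compound 4 is estimated at 70000 nM, with an expected range of 20000 nM to 200000 nM.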

Compound 4, half-maximal inhibitory concentration: 29100 nM
Estimate against measurement, compound 4: 2.4-fold (0.38 log units) above, within the range that was stated.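

In this assay, the phenyl on an oxygen on a saturated carbon turns out to tolerate some substitution, since a substituted ring can bring a reading back from the limit, as an at least 3.4-fold lower number from compound 3 to compound 4 (0.53 log units; beyond the scatter) and an at least 3.4-fold lower number from compound 2 to compound 4 (0.53 log units; beyond the scatter) show. Trifluoromethoxy in place of hydrogen on an aromatic carbon still costs activity, but only modestly, with a 2.1-fold higher number from compound 1 to compound 4 (0.32 log units; beyond the scatter). Compound 2 and compound 3 are now the only ones left at a limit: the limit of > 100000 nM in this assay, at which 2 of the 4 values shown sit.

The change to 4-(trifluoromethoxy)phenyl alters both the group and its place on the ring, so 4-(trifluoromethyl)phenyl and 3-(trifluoromethoxy)phenyl would be needed to tell those two effects apart. On these data alone, the step between compound 2 and compound 3 cannot be read, and how a methoxy group or an amine on that phenyl would behave remains open.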